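The source may hold more compounds than are shown below. What is called first, only, known or untested is meant among the compounds shown, and "the series" means these compounds.

Compound 2, `Cc1ccc(C(=O)/C=C/c2ccc3c(c2)B(O)OC3)cc1`, is the compound from which this step starts. Going by the values given here, in a functional assay on MDA-MB-231 cells (Homo sapiens) for cytotoxicity, read by MTT assay, with a stated time of 48 h (a higher number here means a weaker inhibitor, a lower number a stronger inhibitor), compound 2 gives 6500 nM, the lowest of the two numbers measured so far. Its nearest neighbour is compound 1, `O=C(/C=C/c1ccc2c(c1)B(O)OC2)c1ccc(Br)cc1`, which in this assay gives 9500 nM; the step of a 1.5-fold lower number from compound 1 to compound 2 (0.16 log units; within the scatter) lies within the scatter, so the two compounds cannot be told apart on these numbers.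

Compound 3, `O=C(/C=C/c1ccc2c(c1)B(O)OC2)c1ccc(O)cc1`, has not yet been measured. It differs from compound 2 in one place: hydroxy in place of methyl on an aromatic carbon. Among the compounds with values here, the only measured step that bears on this change is the one between compound 1 and compound 2, a different exchange at the same aromatic carbon, and that step was within the scatter. Within the data shown here, no measured step involves a hydroxy group, so nothing in the data points to a move in either direction beyond the usual scatter. Compound 3 is therefore expected to give about 6500 nM in this assay, within a range from 2500 nM to 17000 nM, which means an expected step of no change at the digits printed from compound 2 to compound 3 (within the scatter).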

Compound 3, half-maximal inhibitory concentration: 25600 nM
Compound 3: the middle estimate sits 3.9-fold (0.60 log units) below what was measured, outside the stated range (above it).
By their numbers in this assay, from the lowest: compounds 2 and 1 (each within the scatter of the next); then compound 3.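

In this assay, the aromatic carbon para to a large group turns out not to be indifferent to what it carries: hydroxy in place of methyl gives a 3.9-fold higher number from compound 2 to compound 3 (0.60 log units; beyond the scatter) and hydroxy in place of bromo gives a 2.7-fold higher number from compound 1 to compound 3 (0.43 log units; beyond the scatter), both steps modest but beyond the scatter. Going by these compounds alone, the earlier exchange of bromo for methyl at this carbon could not be told from the scatter, so this is the first sign that a change here can move the number, and in both steps hydroxy goes with the weaker inhibitor. Nothing given here explains why the number moves with this exchange.

With only methyl, bromo and hydroxy shown at this carbon, it remains open whether the shift belongs to hydroxy alone or would also appear with an amine, a methoxy group or a carboxylic acid in the same place. From the compounds shown here alone, it is also open whether a hydroxy group elsewhere on this ring would move the number as it does here, and whether any group at this carbon could take the number clearly lower than methyl or bromo do.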